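Methoxy in Place of Chloro on the Aryl Ring

A few compounds are considered here, and "the series" means these few. Any claim that something is new, unique, unknown or untested is made for them only; others in the source may bear on it.

Compound 1 `S=C(Nc1ccccc1)N1N=C(c2ccc(Cl)cc2)CC1c1ccc2c(c1)OCCO2` gives 195000 nM in a functional assay on A-375 cells (Homo sapiens) for antiproliferative activity, read by MTT assay, with a stated time of 48 h; a lower number here means a stronger inhibitor of growth, a higher number a weaker inhibitor of growth.
Compound 2 `S=C(Nc1ccccc1)N1N=C(c2ccccc2Br)CC1c1ccc2c(c1)OCCO2` gives only a limit of the assay, > 200000 nM.
Compound 3 `S=C(Nc1ccccc1)N1N=C(c2cccc(Cl)c2)CC1c1ccc2c(c1)OCCO2` gives only a limit of the assay, > 200000 nM.

All three compounds share one core and differ only in the aryl group on the carbon with a double bond to nitrogen. For the measured compounds named here, compound 1 is the only one with a number in this assay; compound 2 and compound 3 reach (the limit of > 200000 nM in this assay, at which 2 of the 3 values shown sit). So the step of an at least 1.0-fold higher number from compound 1 to compound 2 (0.01 log units; that floor lies within the scatter) and the step of an at least 1.0-fold higher number from compound 1 to compound 3 (0.01 log units; that floor lies within the scatter) are read as floors within the scatter, and the step that the two limits leave unreadable from compound 2 to compound 3 cannot be read at all. Compound 3 therefore stands at the limit, with no number.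

Compound 4 `COc1cccc(C2=NN(C(=S)Nc3ccccc3)C(c3ccc4c(c3)OCCO4)C2)c1` differs from compound 3 by methoxy in place of chloro on an aromatic carbon. Going by the values given here, no measured step bears on methoxy, and the steps that are known all sit within the scatter or are unreadable. Compound 4 is thus expected to behave like compound 3 in this assay, with an expected step of a number no higher from compound 3 to compound 4 (the limit leaves the size open). The estimate for compound 4 is 200000 nM, ranging from 100000 nM to 400000 nM.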

Compound 4, concentration for 50% growth inhibition: 520 nM
The estimate for compound 4 lay 380-fold (2.59 log units) above the measured number; the measured number lies below the stated range.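

The earlier compounds shown here, all carrying a halogen on this aryl ring, gave no sign that the ring mattered, but this position proves highly sensitive in this assay: methoxy in place of chloro gives an at least 380-fold lower number from compound 3 to compound 4 (2.58 log units; beyond the scatter). The 3-methoxyphenyl group also separates compound 4 from the other two compounds, with an at least 380-fold lower number from compound 2 to compound 4 (2.58 log units; beyond the scatter) and a 380-fold lower number from compound 1 to compound 4 (2.57 log units; beyond the scatter). The first two of these steps are floors rather than full sizes, because compound 2 and compound 3 carry only limits: the limit of > 200000 nM in this assay, at which 2 of the 4 values shown sit.

Compound 4 is the only methoxy compound shown, so it remains open whether methoxy needs this place on the ring or would act as strongly elsewhere on it. Going by these compounds, whether a hydroxyl, an ethoxy or an amine in the same place would also give a low number is equally open.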